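The source may hold more compounds than are shown below. What is called first, only, known or untested is meant among the compounds shown, and "the series" means these compounds.

Measured compounds:
Compound 1 `CC(C)(C)C(=O)N1CCCn2nc(COc3ccccc3)cc21`: 64%
Compound 2 `O=C(C1CC1)N1CCCn2nc(COc3ccccc3)cc21`: 61%
Compound 3 `O=C(c1ccccc1)N1CCCn2nc(COc3ccccc3)cc21`: 63%

All three share one core and differ only in the group on the carbonyl carbon of the amide. In a functional assay on HEK293 cells for positive allosteric modulation of metabotropic glutamate receptor 5 (Homo sapiens), read by calcium flux (on this read-out lower numbers stand for smaller maximal responses and higher numbers for larger maximal responses), compound 1 gives 64%, compound 2 gives 61% and compound 3 gives 63%. Compound 2 carries the smallest of the three numbers, but the gaps are small: a number 2 percentage points higher from compound 2 to compound 3 (within the scatter) and a number 3 percentage points lower from compound 1 to compound 2 (within the scatter) both sit within the usual scatter, as does a number 1 percentage points lower from compound 1 to compound 3 (within the scatter).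

Compound 4 `O=C(c1ccco1)N1CCCn2nc(COc3ccccc3)cc21` has not yet been measured. It arises from compound 2 by the change (furan-2-yl in place of cyclopropyl on a carbonyl carbon), which reads, one bond further out, as cyclopropylcarbonyl to (furan-2-yl)carbonyl. All three measured steps touch the same carbonyl carbon, exchanging tert-butyl, cyclopropyl and phenyl, and none of them moved the maximal response beyond the scatter. Compound 3 already shows that an aromatic ring in this place gives a number close to that of compound 2, so compound 4 with its furan-2-yl is expected to behave alike in this assay . The estimated step is a number 1 percentage points higher from compound 2 to compound 4 (within the scatter), meaning no change beyond the scatter. Compound 4 is therefore expected to give 62%, within a range from 52% to 72%.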

Compound 4, largest response reached (reported as percent of maximum), in percent of the reference or control that the assay uses: < 15%
Compound 4: only a limit was reported; the forecaster's own chance of this, stated with the estimate: 0%; middle value at least 47 percentage points away from the limit.
By their numbers in this assay, from the lowest: compounds 2, 3 and 1 (each within the scatter of the next). At a limit, below all of these: compound 4.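

For compound 4, the reading in this assay is a limit of the assay and not a number: the limit of < 15% in this assay, at which 1 of the 4 values shown sits.

The earlier compounds shown here suggested that the group on this carbonyl carbon mattered little, as tert-butyl, cyclopropyl and phenyl all gave values within the scatter of one another, but furan-2-yl breaks that picture, with a number at least 46 percentage points lower from compound 2 to compound 4 (beyond the scatter), a number at least 48 percentage points lower from compound 3 to compound 4 (beyond the scatter) and a number at least 49 percentage points lower from compound 1 to compound 4 (beyond the scatter). An aromatic ring as such therefore does not decide the maximal response here, since compound 3, with its phenyl, stays with compound 1 and compound 2, while the five-membered aromatic ring with its oxygen atom does not.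

The compounds shown leave open which feature of furan-2-yl goes with this loss, whether the ring oxygen, its place in the ring or the ring size. Thiophen-2-yl, furan-3-yl and tetrahydrofuran-2-yl on the same carbonyl carbon would address that question, and the limit leaves open how far the response of compound 4 actually falls.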